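Bromine on the Phenyl Ring of Two Thiophene Amides

The compounds below may be only part of what the source reports. "The series", "measured", "known", "first", "only" and "open" are said of these compounds alone.

Measured so far in an assay on H9c2 cells for inhibition of tumor necrosis factor receptor superfamily member 6 (Rattus norvegicus), with stated times of 30 min and 6 h; a lower number here means that less compound is needed, a higher number that more compound is needed for the effect:
compound 1 `COC(=O)c1sccc1NC(=O)CCSc1ccccc1` gives 501 nM
compound 2 `COC(=O)c1sccc1NC(=O)CCSc1ccc(Br)cc1` gives 1290 nM
compound 3 `COC(=O)c1ccsc1NC(=O)CSc1ccccc1` gives 724 nM

Compound 1 and compound 2 share one core and differ in a single spot: bromo in place of hydrogen on an aromatic carbon. This change carried a step of a 2.6-fold higher number from compound 1 to compound 2 (0.41 log units; beyond the scatter), so the brominated compound 2 needs more material than compound 1 for the same effect.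

Compound 3 is built on a different core, one in which the ester and the amide sit on the other positions of the thiophene and the chain to the sulfur is shorter. The difference between the two cores is not broken down here. In this assay compound 3 and compound 1 give numbers that lie within the usual scatter of each other, so no order between them can be claimed; compound 2 is the only one of the three whose number stands apart.

Compound 4 `COC(=O)c1ccsc1NC(=O)CSc1ccc(Br)cc1` is not yet measured. It differs from compound 3 exactly as compound 2 differs from compound 1: bromo in place of hydrogen on an aromatic carbon. The change and its place read the same in both pairs, so it is the same change on a second core.

Going by the values given here, the only guide for compound 4 is the single measured step from compound 1 to compound 2, and the expected step from compound 3 to compound 4 is therefore set close to it, at a 2.5-fold higher number from compound 3 to compound 4 (0.40 log units; beyond the scatter). With just one earlier example, a range is needed: compound 4 is estimated to give 1800 nM in this assay, expected to fall between 900 nM and 3600 nM.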

Compound 4, half-maximal effective concentration: 759 nM
Beside the measured number, compound 4's estimate is 2.4-fold (0.38 log units) above it, and the stated range ends above it.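

On the second core, the change from phenyl to 4-bromophenyl comes with a 1.0-fold higher number from compound 3 to compound 4 (0.02 log units; within the scatter) in this assay, a step within the scatter, so no effect of the bromo group can be claimed on this core. On the first core the same change gave a step beyond the scatter, yet the two steps still cannot be told apart from each other: the same change on two cores in this assay, a 2.6-fold higher number (0.41 log units; beyond the scatter) from compound 1 to compound 2 and a 1.0-fold higher number (0.02 log units; within the scatter) from compound 3 to compound 4, 2.5-fold (0.39 log units) apart, within the scatter of two such steps. Going by these compounds alone, the data therefore do not show that the change carries over from one core to the other with the same size, and they do not show that the two cores respond differently either, since each core offers only a single pair and the gap between the two steps is no larger than two repeated steps could show by chance.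

The compounds shown carry only hydrogen or bromo at this place on the phenyl ring, so it remains open whether chloro, methoxy or an amine there would behave alike on both cores. As far as these compounds go, it also remains open how the length of the chain to the sulfur and the placement of the ester and amide on the thiophene each count, as the two cores differ in both at once.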